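Bromo in place of chloro on a benzisoxazole sulfonamide core

The source may report more compounds than this note shows. Statements on the series, on what has been measured and on what is new or still open speak of the compounds shown alone.

Measured compounds in a functional assay on the whole organism (strain STD-dd) with Mus musculus as the target, in the maximal electroshock model, with a stated time of 2 h; on this read-out higher numbers stand for an effect only at larger amounts of compound and lower numbers for an effect already at smaller amounts:
compound 1, `NS(=O)(=O)Cc1noc2ccc(Cl)cc12`: 14 mg/kg
compound 2, `CNS(=O)(=O)Cc1noc2ccc(Cl)cc12`: 20 mg/kg

Going by the values given here, compound 2 has the highest of the two numbers in this assay, and its nearest neighbour is compound 1, with a number lower by an amount that is within the scatter; the only measured step, a 1.4-fold higher number from compound 1 to compound 2 (0.15 log units; within the scatter), therefore shows no difference that can be trusted between the two. Compound 3, `CNS(=O)(=O)Cc1noc2ccc(Br)cc12`, differs from compound 2 in one place: bromo in place of chloro on an aromatic carbon.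

Among the compounds with values here, no measured step bears directly on this change, since the only one available concerns the sulfonamide nitrogen and not the aromatic ring. The exchange keeps the count of heavy atoms, donors and acceptors unchanged, so compound 3 is expected to sit close to compound 2, with a step of no change at the digits printed from compound 2 to compound 3 (within the scatter) that is not expected to go beyond the scatter in either direction. For compound 3 the expected value in this assay is therefore 20 mg/kg, estimated to lie between 10 mg/kg and 40 mg/kg.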

Compound 3, dose for half-maximal effect: 15 mg/kg
For compound 3 the middle estimate is 1.3-fold (0.12 log units) above the measured one; the range from low to high includes it.
By their numbers in this assay, from the lowest: compounds 1, 3 and 2 (each within the scatter of the next).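

In this assay the exchange of chloro for bromo on the aromatic carbon gives a 1.3-fold lower number from compound 2 to compound 3 (0.12 log units; within the scatter), so for this pair the read-out does not separate the two halogens at this position. The earlier compounds shown here had varied only the sulfonamide nitrogen, with a 1.4-fold higher number from compound 1 to compound 2 (0.15 log units; within the scatter); compound 3 extends the comparison to the six-membered aromatic ring of the shared core, and this step also stays within the scatter. Nothing measured here offers a reason for the outcome of this exchange.

The compounds shown carry only chloro or bromo at this aromatic carbon, so it remains open whether plain hydrogen, a methoxy group, an amine or a carboxylic acid at the same place would also leave the number within the scatter of compound 2. On these data alone, it is equally open whether bromo would behave in the same way with the unsubstituted sulfonamide of compound 1, or whether a longer chain such as propyl on the sulfonamide nitrogen would change the number beyond the scatter.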